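This account rests on a few compounds, and the source may have more. Where it says the series, first, only, none or still open, it means among the compounds named here.

Measured so far:
- compound 1 `CNC(=O)CCCCCCCn1nc(-c2cnc3[nH]ccc3c2)c2c(N)ncnc21`: 51000 nM
- compound 2 `Nc1nc2cc(-c3nn(CCC(=O)NO)c4ncnc(N)c34)ccc2o1`: > 150000 nM

Going by the values given here, in a functional assay on A549 cells (Homo sapiens) for inhibition, read by MTT assay, with a stated time of 72 h (a lower number here means a stronger inhibitor, a higher number a weaker inhibitor), compound 1 gives 51000 nM, and this is the only number that has come out of the study. Compound 2 gives only a limit in this assay, > 150000 nM, so no number is known for it; this is the case for (the limit of > 150000 nM in this assay, at which 1 of the 2 values shown sits). Compound 1 therefore stands as a weak inhibitor, and compound 2 has not shown inhibition within the range tested.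

Compound 3 `Nc1ncnc2c1c(-c1cnc3[nH]ccc3c1)nn2CCCC(=O)NO` has not yet been measured. It differs from compound 1 by hydroxycarbamoyl in place of 4-(methylcarbamoyl)butyl on a saturated chain carbon, three bonds along the chain from an aromatic nitrogen. Among the compounds with values here, no step between two measured compounds resembles this change, so its effect is open. Compound 1 is expected to change by a 1.3-fold lower number from compound 1 to compound 3 (0.11 log units; within the scatter) on going to compound 3, a step of a size not clearly beyond the scatter. Compound 3 is therefore expected to give 40000 nM in this assay, within a range from 8000 nM to 200000 nM.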

Compound 3, half-maximal inhibitory concentration: > 150000 nM
Compound 3 was reported as a limit; the forecaster's own chance of this, stated with the estimate: 30%; middle value at least 3.7-fold (0.57 log units) from the limit.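

Going by these compounds alone, replacing 4-(methylcarbamoyl)butyl with hydroxycarbamoyl, on a saturated chain carbon three bonds along the chain from an aromatic nitrogen, gives the first step that can be read at this position. In this assay, the change gives an at least 2.9-fold higher number from compound 1 to compound 3 (0.46 log units; beyond the scatter), so the weak inhibition seen with the longer group is not kept. The result for compound 3 is a limit and not a number, so this step gives only a minimum size, and the same limit now holds for most of the compounds shown: the limit of > 150000 nM in this assay, at which 2 of the 3 values shown sit.

This single change alters both the length of the chain and the group at its end, and the compounds shown cannot separate the two. A carboxylic acid on the same chain, or hydroxycarbamoyl on a longer chain, would be needed to tell these two effects apart.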